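The source may report more compounds than this note shows. Statements on the series, on what has been measured and on what is new or still open speak of the compounds shown alone.

Working notes on the series. The shared core is that of compound 1 `O=S(=O)(Nc1ccc(-c2nc3ccccc3o2)cc1)c1ccccc1O`. In an assay on isolated protein for inhibition of malate dehydrogenase, mitochondrial (Sus scrofa), with stated times of 45 min and 30 min (a higher number here means a weaker inhibitor, a lower number a stronger inhibitor), compound 1 gives > 63000 nM, which is a limit of the assay and not a number. Compound 2 `CS(=O)(=O)Nc1ccc2oc(-c3ccccc3)nc2c1` gives > 63000 nM in this assay, again only a limit. Compound 3 `O=[N+]([O-])c1cc(S(=O)(=O)Nc2ccc3oc(-c4ccccc4)nc3c2)ccc1Cl` likewise gives > 63000 nM in this assay, also a limit. Within the data shown here, compound 1 therefore stands nowhere on a scale of numbers: every value so far in this assay is the same limit, as the limit of > 63000 nM in this assay, at which 3 of the 3 values shown sit, records.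

Compound 4 `O=S(=O)(Nc1ccc(-c2nc3ccccc3o2)cc1)c1ccc(Cl)cc1` is not yet measured. It differs from compound 1 in one place: 4-chlorophenyl in place of 2-hydroxyphenyl on a sulfonyl sulfur. Among the measured compounds shown here, no step between measured compounds exists, since none of the three measured compounds has a number in this assay. The step that the limit leaves unreadable from compound 1 to compound 4 is expected to be none beyond the scatter, given that all measured members sit at the limit (the limit of > 63000 nM in this assay, at which 3 of the 3 values shown sit). For compound 4 the estimated value in this assay is 80000 nM, with a range of 20000 nM to 300000 nM, and the more likely outcome is that this assay again reports only a limit.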

Compound 4, half-maximal inhibitory concentration: > 63000 nM
Compound 4 ended at the assay's limit; the forecaster's own chance of this, stated with the estimate: 75%; the middle value is on the limit's open side.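

In this assay compound 4 gives > 63000 nM, a limit of the assay and not a number. Among these compounds, compound 1 also has only a limit, so no step between compound 1 and compound 4 can be read. The compounds shown leave open whether any change to the shared core gives a measurable value in this assay.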